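Ortho Trifluoromethyl for Chloro on a Sulfonylguanidine Core

The source may report more compounds than this note shows. Statements on the series, on what has been measured and on what is new or still open speak of the compounds shown alone.

Compound 2 `Cc1cc(-c2ccccc2)n(/C(N)=N/S(=O)(=O)c2cc(C)c(Cl)cc2SCc2ccc(Cl)cc2)n1` gives 3000 nM in a functional assay on HeLa cells (Homo sapiens) for cytotoxicity, read by MTT assay, with a stated time of 72 h; a lower number here means a stronger inhibitor, a higher number a weaker inhibitor. Compound 1 `Cc1cc(-c2ccccc2)n(/C(N)=N/S(=O)(=O)c2cc(C)c(Cl)cc2SCc2ccc(C(F)(F)F)cc2)n1` carries a trifluoromethyl in place of chloro on an aromatic carbon, and in this assay compound 1 gives 19000 nM; that change gave a 6.3-fold higher number from compound 2 to compound 1 (0.80 log units; beyond the scatter). Compound 3 `Cc1cc(S(=O)(=O)/N=C(\N)n2nccc2-c2ccccc2)c(SCc2ccccc2Cl)cc1Cl` has a different core; the difference between the two cores is not broken down here. In this assay compound 3 gives 19000 nM. Compound 4 `Cc1cc(S(=O)(=O)/N=C(\N)n2nccc2-c2ccccc2)c(SCc2ccccc2C(F)(F)F)cc1Cl` differs from compound 3 by the same kind of change (trifluoromethyl in place of chloro on an aromatic carbon), though here the place is ortho to a large group rather than para to it. Because a 6.3-fold higher number from compound 2 to compound 1 (0.80 log units; beyond the scatter) was seen, a weaker number is expected for compound 4, with the step estimated as a 2.6-fold higher number from compound 3 to compound 4 (0.42 log units; beyond the scatter). Compound 4 is therefore expected to give about 50000 nM, between 15000 nM and 150000 nM.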

Compound 4, half-maximal inhibitory concentration: 20000 nM
Beside the measured number, compound 4's estimate is 2.5-fold (0.40 log units) above it; the range from low to high includes it.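

In this assay, trifluoromethyl in place of chloro gave a 1.1-fold higher number from compound 3 to compound 4 (0.02 log units; within the scatter) on this core, so the change left the number essentially where it stood. Its size did not carry over from the other core: the same change on two cores in this assay, a 6.3-fold higher number (0.80 log units; beyond the scatter) from compound 2 to compound 1 and a 1.1-fold higher number (0.02 log units; within the scatter) from compound 3 to compound 4, 6.0-fold (0.78 log units) apart, beyond the scatter of two such steps. The two pairs differ both in their core and in where the change sits, so these compounds do not show which of the two accounts for the gap, and two pairs cannot set a rule for the whole series.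

Still open, on these data alone, is how the same change behaves at each place on each core. Also open, as far as these compounds go, is what other groups at this position, such as methyl, methoxy or a nitrile, would do.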